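Varying the amine terminus of a coumarin-prenylphenol amide

The source may hold more compounds than are shown below. What is called first, only, known or untested is meant among the compounds shown, and "the series" means these compounds.

Measured compounds:
Compound 1 `CCCNCCCOc1ccc2cc(NC(=O)c3ccc(O)c(CC=C(C)C)c3)c(=O)oc2c1C` gives 990 nM in a functional assay on SK-BR-3 cells (Homo sapiens) for antiproliferative activity; a higher number here means a weaker inhibitor, a lower number a stronger inhibitor.
Compound 2 `CC(C)=CCc1cc(C(=O)Nc2cc3ccc(OCCCNCC(C)C)c(C)c3oc2=O)ccc1O` gives 1030 nM in this assay.
Compound 3 `CC(C)=CCc1cc(C(=O)Nc2cc3ccc(OCCCN(C)C4CCCCC4)c(C)c3oc2=O)ccc1O` gives 970 nM in this assay.

Compound 1 has the second highest of the three numbers; all three lie within the scatter of one another, so no order among them can be claimed. Compound 4 `CC(C)=CCc1cc(C(=O)Nc2cc3ccc(OCCCN(C)Cc4ccccc4)c(C)c3oc2=O)ccc1O` differs from compound 1 by benzyl(methyl)amino in place of propylamino on a saturated chain carbon, three bonds along the chain from an oxygen on an aromatic ring. The step bearing on this is a 1.0-fold lower number from compound 1 to compound 3 (0.01 log units; within the scatter), and a 1.1-fold lower number from compound 2 to compound 3 (0.03 log units; within the scatter) points the same way: both replace a chain amine with a methylated, ring-bearing amine and neither leaves the scatter. Compound 4 is therefore expected to change by a 1.0-fold lower number from compound 1 to compound 4 (0.02 log units; within the scatter), with no shift beyond the scatter. The estimate for compound 4 is 950 nM, expected between 450 nM and 2000 nM.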

Compound 4, half-maximal inhibitory concentration: 10700 nM
Compound 4: the middle estimate sits 11-fold (1.05 log units) below what was measured; measured number above the stated range.
By their numbers in this assay, from the lowest: compounds 3, 1 and 2 (each within the scatter of the next); then compound 4.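

In this assay, among the compounds shown here, the amine terminus on this saturated chain carbon proves not to be indifferent: benzyl(methyl)amino gives an 11-fold higher number from compound 1 to compound 4 (1.03 log units; beyond the scatter) and a 10-fold higher number from compound 2 to compound 4 (1.02 log units; beyond the scatter), which the earlier compounds, all within the scatter, did not foreshadow. Benzyl in place of cyclohexyl on the amine nitrogen gives an 11-fold higher number from compound 3 to compound 4 (1.04 log units; beyond the scatter), so a methylated, ring-bearing amine is not enough to cause the drop, as compound 3 carries one too. No measurement here accounts for the drop. As far as these compounds go, whether a benzylamino or a 2-phenylethyl(methyl)amino terminus would behave like compound 4 or like compound 3 stays open.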